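A few compounds are considered here, and "the series" means these few. Any claim that something is new, unique, unknown or untested is made for them only; others in the source may bear on it.

The series shares one core, seen in compound 1 `COc1cccc(-c2c(-c3ccccc3)c(-c3ccccc3)n3ccc(C#N)cc23)c1`, compound 2 `COc1ccccc1-c1c(-c2ccccc2)c(-c2ccccc2)n2ccc(C#N)cc12` and compound 3 `Cc1ccc(S(=O)(=O)Oc2c(-c3ccccc3)c(-c3ccccc3)n3ccc(C#N)cc23)cc1`. In a functional assay for inhibition, with a stated time of 30 min (a lower number here means a stronger inhibitor, a higher number a weaker inhibitor), compound 1 gives > 100000 nM, which is a limit of the assay. Compound 2 gives > 100000 nM, also a limit. For the measured compounds named here, compound 3 gives 3640 nM, the only actual number so far.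

Compound 4 `N#Cc1ccn2c(-c3ccccc3)c(-c3ccccc3)c(C(O)c3ccccc3)c2c1` differs from compound 3 by hydroxy(phenyl)methyl in place of ((4-methylphenyl)sulfonyl)oxy on an aromatic carbon. In words, hydroxy(phenyl)methyl stands in place of ((4-methylphenyl)sulfonyl)oxy on an aromatic carbon.

Going by the values given here, two measured steps bear on this exchange: an at least 27-fold lower number from compound 1 to compound 3 (1.43 log units; beyond the scatter) and an at least 27-fold lower number from compound 2 to compound 3 (1.43 log units; beyond the scatter). Both are large, and each has a limit at one end. The remaining step, a step that the two limits leave unreadable from compound 1 to compound 2, gives no size. Losing ((4-methylphenyl)sulfonyl)oxy is therefore expected to raise the number in this assay, since the methoxyphenyl compound 1 sits at > 100000 nM. The hydroxy(phenyl)methyl group is a different replacement, so a moderate rise is expected rather than the full gap. The expected change is a 5.5-fold higher number from compound 3 to compound 4 (0.74 log units; beyond the scatter). For compound 4 the estimated value is 20000 nM, within an expected range of 3000 nM to 100000 nM.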

Compound 4, half-maximal inhibitory concentration: 35800 nM
For compound 4 the middle estimate is 1.8-fold (0.25 log units) below the measured one, within the range that was stated.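

In this assay, this position now holds a second group with a readable number, so a replacement for ((4-methylphenyl)sulfonyl)oxy can be sized with no limit at either end: a 9.8-fold higher number from compound 3 to compound 4 (0.99 log units; beyond the scatter). Measurable inhibition is therefore not confined to ((4-methylphenyl)sulfonyl)oxy, although that group remains the stronger of the two. Hydroxy(phenyl)methyl also separates from the methoxyphenyl groups, with an at least 2.7-fold lower number from compound 2 to compound 4 (0.44 log units; beyond the scatter) and an at least 2.7-fold lower number from compound 1 to compound 4 (0.44 log units; beyond the scatter), and both of these steps rest on a limit: the limit of > 100000 nM in this assay, at which 2 of the 4 values shown sit.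

Going by these compounds, it remains open whether the hydroxy or the phenyl part of hydroxy(phenyl)methyl accounts for that separation, and how an aminomethyl group or a carboxylic acid would read at this position. The two phenyl groups and the nitrile stay constant throughout, so the compounds shown say nothing about those places.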